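Amide aryl variation on the shared core

The source may hold more compounds than are shown below. What is called first, only, known or untested is meant among the compounds shown, and "the series" means these compounds.

Among the compounds with values here, in a functional assay on GTL 16 cells for antiproliferative activity against GTL 16 cell line (Homo sapiens), read by CCK-8 assay, with a stated time of 72 h (on this read-out higher numbers stand for weaker inhibition and lower numbers for stronger inhibition), compound 2 `COc1ccccc1C(=O)Nc1cccc(-c2oc3cc(-c4ccc(F)cc4)ccc3c(=O)c2O)c1` gives 6370 nM, the lowest of the three numbers measured so far; compound 3 `O=C(Nc1cccc(-c2oc3cc(-c4ccc(F)cc4)ccc3c(=O)c2O)c1)c1cccc(F)c1` gives 15800 nM and compound 1 `O=C(Nc1cccc(-c2oc3cc(-c4ccc(F)cc4)ccc3c(=O)c2O)c1)c1ccccc1F` gives 17400 nM, both beyond the scatter from it. The steps read a 2.7-fold lower number from compound 1 to compound 2 (0.44 log units; beyond the scatter) and a 2.5-fold higher number from compound 2 to compound 3 (0.39 log units; beyond the scatter), while a 1.1-fold lower number from compound 1 to compound 3 (0.04 log units; within the scatter). Compound 4 `Cc1cc(C(=O)Nc2cccc(-c3oc4cc(-c5ccc(F)cc5)ccc4c(=O)c3O)c2)ccc1F` differs from compound 2 by 4-fluoro-3-methylphenyl in place of 2-methoxyphenyl on a carbonyl carbon. Both measured exchanges of the 2-methoxyphenyl for a fluorine-bearing ring gave a modest rise in number, so a rise of similar size is expected here, a 2.4-fold higher number from compound 2 to compound 4 (0.37 log units; beyond the scatter). Compound 4 is therefore estimated at 15000 nM, with a range from 6000 nM to 40000 nM.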

Compound 4, half-maximal inhibitory concentration: 12100 nM
For compound 4 the middle estimate is 1.2-fold (0.09 log units) above the measured one; the measured number falls inside the stated range.
By their numbers in this assay, from the lowest: compounds 2, 4, 3 and 1 (each within the scatter of the next, the first and the last beyond it).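

In this assay the 4-fluoro-3-methylphenyl on the carbonyl carbon stays within the scatter of all three earlier aryl groups (a 1.9-fold higher number from compound 2 to compound 4 (0.28 log units; within the scatter)) (a 1.3-fold lower number from compound 3 to compound 4 (0.12 log units; within the scatter)) (a 1.4-fold lower number from compound 1 to compound 4 (0.16 log units; within the scatter)). Compound 4 therefore joins neither side of the separation between compound 2 and the fluorophenyl compounds 1 and 3, which remains beyond the scatter. No measurement available here explains these numbers.

Still open, from the compounds shown here alone, is whether a non-aromatic group such as cyclohexyl, or a ring bearing a carboxylic acid or an aminomethyl group, would move the number beyond the scatter from compound 2.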